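This account rests on a few compounds, and the source may have more. Where it says the series, first, only, none or still open, it means among the compounds named here.

Measured compounds in the series:

compound 1 `CN(C)CCCCN(C(=O)O)c1cccc(Cn2nc(-c3ccc(F)cc3)c3ccccc3c2=O)c1`: 8510 nM
compound 2 `CN(C)CCCCNC(=O)Nc1ccc(CN2N=C(c3ccc(F)cc3)C3C=CC=CC3C2=O)cc1`: 46600 nM
compound 3 `CN(C)CCCCOC(=O)Nc1ccc(Cn2nc(-c3cncnc3)c3ccccc3c2=O)cc1`: 65300 nM

All three were read in an ADME assay on Huh-7 cells (Homo sapiens) for cytotoxicity, read by MTT assay, with a stated time of 48 h; on this read-out lower numbers stand for higher toxicity in this test and higher numbers for lower toxicity in this test. Compound 3 holds the highest of the three numbers; compound 2 is nearest to it, and the two lie within the scatter of each other, so no order between them is claimed. Compound 1 stands furthest from compound 3, and that gap is beyond the scatter. No pair among the measured compounds differs in only one place, so no single step is shown, and the three values are read side by side rather than as a chain.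

Compound 4 `COc1ccc(-c2nn(Cc3ccc(NC(=O)OCCCCN(C)C)cc3)c(=O)c3ccccc23)cc1` has not been measured. Against compound 3 the change is 4-methoxyphenyl in place of pyrimidin-5-yl on an aromatic carbon. No comparable exchange exists among the measured compounds, so the expected size of the step in this assay rests on the spread of the three numbers alone. The change is expected to shift the number down, toward the middle of the measured range, by no more than a modest amount, with a step within the scatter fully possible. For compound 4 the estimate is 45000 nM, with a range from 15000 nM to 110000 nM, meaning an expected step of a 1.5-fold lower number from compound 3 to compound 4 (0.16 log units; within the scatter).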

Compound 4, half-maximal cytotoxic concentration: 20300 nM
Estimate against measurement, compound 4: 2.2-fold (0.35 log units) above; low and high end bracket the measured number.
By their numbers in this assay, from the lowest: compound 1; then compound 4; then compounds 2 and 3 (each within the scatter of the next).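

In this assay, among these compounds, placing 4-methoxyphenyl instead of pyrimidin-5-yl on the aromatic carbon next to the ring nitrogen gives a 3.2-fold lower number from compound 3 to compound 4 (0.51 log units; beyond the scatter), the first step that can be read at a single place, and it shows that this position alone can move the number while the rest of the structure stays fixed. The direction is toward higher toxicity in this test, and the exchange removes both ring nitrogens of the leaving group while bringing in a carbon-only ring that carries a methoxy group, so this one step joins two structural changes without separating them. No measurement shown here bears on the reason for the step.

On these data alone, it remains open whether the shift follows the loss of the ring nitrogens or the gain of the methoxy group, a question that plain phenyl or pyridin-3-yl at this position would help to separate. Steps from compound 1 or compound 2 to compound 4 cannot be read, since each of those compounds differs from compound 4 in more than one place.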